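A few compounds are considered here, and "the series" means these few. Any claim that something is new, unique, unknown or untested is made for them only; others in the source may bear on it.

Of the compounds shown here, three that share one core have been measured in an ADME assay for pharmacokinetics, read by LC-MS, in phosphate buffer, with a stated time of 72 h, at pH 7.4, tested at 250 uM; a higher number here means that the compound lasts longer, a lower number that the compound disappears faster. Compound 1 `C#Cc1cc(C(F)(F)F)cc(C(F)(F)F)c1` gives 1.6 h. Compound 2 `O=C(CBr)c1cc(C(F)(F)F)cc(C(F)(F)F)c1` reaches only a limit of the assay, namely < 0.017 h. Compound 3 `FC(F)(F)c1cc(C2CO2)cc(C(F)(F)F)c1` likewise stands at a limit of the assay, namely > 50 h. Of the three values shown, compound 3 thus sits at the top, though only as a limit (the limit of > 50 h in this assay, at which 1 of the 3 values shown sits), while the bottom value is also a limit (the limit of < 0.017 h in this assay, at which 1 of the 3 values shown sits). All three steps are large: an at least 94-fold lower number from compound 1 to compound 2 (1.97 log units; beyond the scatter), an at least 31-fold higher number from compound 1 to compound 3 (1.49 log units; beyond the scatter) and an at least 2900-fold higher number from compound 2 to compound 3 (3.46 log units; beyond the scatter). Compound 4 `FC(F)(F)c1cc(S)cc(C(F)(F)F)c1` differs from compound 3 by sulfanyl in place of oxiran-2-yl on an aromatic carbon. For the measured compounds named here, no measured step involves sulfanyl, so the earlier steps bear on this change only by showing that exchanging the group on this aromatic carbon can shift the half-life across the full span of this assay. A large step downward is therefore expected, though its size is uncertain. Compound 4 is expected to give 10 h, within a range from 1 h to 50 h. This corresponds to an expected at least 5.0-fold lower number from compound 3 to compound 4 (0.69 log units; beyond the scatter).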

Compound 4, half-life: > 50 h
Compound 4 gave a limit, no number (the forecaster's own chance of this, stated with the estimate: 25%); middle value at least 5.0-fold (0.69 log units) away from the limit.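

In this assay compound 4 stands at a limit, > 50 h, and the step from compound 3 to compound 4 cannot be read, so sulfanyl and oxiran-2-yl are not told apart on this aromatic carbon: the limit of > 50 h in this assay, at which 2 of the 4 values shown sit. Against the other two groups the change is large, with an at least 2900-fold higher number from compound 2 to compound 4 (3.46 log units; beyond the scatter) and an at least 31-fold higher number from compound 1 to compound 4 (1.49 log units; beyond the scatter). The three-membered ring of compound 3 is thus not needed to reach the top limit at this position, since sulfanyl, which has no ring, reaches it too.

On these data alone, how far compound 3 and compound 4 would each lie past the limit stays open, and with it which of the two lasts longer. Also open, as far as these compounds go, is whether an amine, a carboxylic acid or a longer chain on this carbon would reach the same limit.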